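Aryl Group Swapped for an Ester Chain on the Ring Nitrogen

The source may hold more compounds than are shown below. What is called first, only, known or untested is meant among the compounds shown, and "the series" means these compounds.

Compound 2 `CCOC(=O)Cn1cc(CNCCN2CCN(C)CC2)c(-c2ccccc2C)n1` and compound 3 `CSc1ccc(-n2cc(CNCCN3CCN(C)CC3)c(-c3ccccc3C)n2)cc1` share one core. In an ADME assay on Huh-7 cells (Homo sapiens) for cytotoxicity (on this read-out lower numbers stand for higher toxicity in this test and higher numbers for lower toxicity in this test), compound 2 stops at the limit > 20000 nM, a boundary of the test rather than a number. Compound 1 `Cc1ccccc1-c1nn(-c2ccc(F)c(F)c2)cc1CNCCN1CCN(C)CC1` likewise stops at the limit > 20000 nM. The change from compound 2 to compound 3 is 4-(methylsulfanyl)phenyl in place of (ethoxycarbonyl)methyl on an aromatic nitrogen. Among the compounds with values here, the only measured step, a step that the two limits leave unreadable from compound 1 to compound 2, cannot be read because both ends sit at the limit of > 20000 nM in this assay, at which 2 of the 2 values shown sit. Compound 1 already carries an aryl group on that nitrogen without leaving the limit. The step of a number no higher from compound 2 to compound 3 (the limit leaves the size open) is therefore expected to be nothing beyond the scatter. Compound 3 is estimated at 20000 nM, between 8000 nM and 50000 nM.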

Compound 3, half-maximal cytotoxic concentration: 17000 nM
Beside the measured number, compound 3's estimate is 1.2-fold (0.07 log units) above it; measured number inside the range.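

In this assay compound 3 gives 17000 nM, the only read-out among these compounds at this ring nitrogen that is a number and not a limit. The steps are an at least 1.1-fold lower number from compound 2 to compound 3 (0.07 log units; that floor lies within the scatter) and an at least 1.1-fold lower number from compound 1 to compound 3 (0.07 log units; that floor lies within the scatter), so these floors do not show that 4-(methylsulfanyl)phenyl changes the read-out beyond the scatter. The other two compounds remain at a limit of the test: the limit of > 20000 nM in this assay, at which 2 of the 3 values shown sit.

From the compounds shown here alone, how far compound 1 and compound 2 lie past that limit stays open. So does whether an amine or a carboxylic acid on this nitrogen would give a clearly lower number.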